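A few compounds are considered here, and "the series" means these few. Any claim that something is new, unique, unknown or untested is made for them only; others in the source may bear on it.

Measured so far:
- compound 1 `O=C(O)CC1CCN(Cc2cc(Oc3cnc(N4CCNCC4)nc3)nc(-c3cc(Cl)cc(Cl)c3)c2)CC1`: 6%
- compound 2 `CC(=O)NCC1CCN(Cc2cc(Oc3cnc(N4CCN(CCC(C)C(=O)O)CC4)nc3)nc(-c3cc(Cl)cc(Cl)c3)c2)CC1`: 62%

In a functional assay on the whole organism for inhibition, with Mus musculus as the target, at a dose of 10 mg/kg by the oral route (a lower number here means less inhibition, a higher number more inhibition at the dose given (going by the name of the read-out)), compound 1 gives 6%, the lowest of the two numbers; compound 2 gives 62%, a gap well beyond the scatter, though the two structures differ in more than one place.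

Compound 3 `CS(=O)(=O)CCCN1CCN(c2ncc(Oc3cc(CN4CCC(CC(=O)O)CC4)cc(-c4cc(Cl)cc(Cl)c4)n3)cn2)CC1` is not yet measured in this assay. It differs from compound 1 in one place: 3-(methylsulfonyl)propyl in place of hydrogen on an amine nitrogen in a ring.

The direction of the step from compound 1 to compound 3 is not settled by the two measured compounds. An increase in inhibition is expected, estimated as a number 29 percentage points higher from compound 1 to compound 3 (beyond the scatter), because compound 2, which also carries a chain on that ring nitrogen, gives 62%. For compound 3 the estimate in this assay is 35%, range 8% to 65%.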

Compound 3, a percentage reported as inhibition, in the whole organism at one dose (the size of the read-out at that dose, not a potency): -1%
For compound 3 the middle estimate is 36 percentage points above the measured one; measured number outside the range, below it.
By their numbers in this assay, from the lowest: compounds 3 and 1 (each within the scatter of the next); then compound 2.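

In this assay, within the data shown here, 3-(methylsulfonyl)propyl in place of hydrogen on this amine nitrogen in a ring gives the first single-place step: a number 7 percentage points lower from compound 1 to compound 3 (within the scatter). Carrying a chain on this nitrogen therefore does not by itself raise inhibition at this dose, at least for this chain on the core of compound 1. No measurement here bears on why this step stays so small.

Going by these compounds, whether a chain ending in an amine or an amide on this nitrogen would move the read-out remains open.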